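Triazole substituent series: aryl to chloroalkyl step

This account rests on a few compounds, and the source may have more. Where it says the series, first, only, none or still open, it means among the compounds named here.

Of the compounds shown here, three sharing one core have been measured in an ADME assay on HFF cells (Homo sapiens) for cytotoxicity, read by MTT assay, with a stated time of 72 h; a lower number here means a stronger inhibitor, a higher number a weaker inhibitor. Compound 1 `O=C1O[C@H]([C@@H](O)Cn2cc(CNS(=O)(=O)c3ccc(Cl)cc3F)nn2)C(OCc2ccccc2)=C1OCc1ccccc1` gives 20 nM. Compound 2 `C[Si](C)(C)c1cn(C[C@H](O)[C@H]2OC(=O)C(OCc3ccccc3)=C2OCc2ccccc2)nn1` gives 20000 nM. Compound 3 `COc1ccccc1-c1cn(C[C@H](O)[C@H]2OC(=O)C(OCc3ccccc3)=C2OCc2ccccc2)nn1` gives 50 nM, the second highest of the three numbers; compound 1 is its nearest neighbour, with a lower number that is nonetheless beyond the scatter, and compound 2 is the furthest, with a far higher number.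

Going by the values given here, only one measured step changes a single place: a 400-fold lower number from compound 2 to compound 3 (2.60 log units; beyond the scatter), where a group of 8 heavy atoms containing one six-membered aromatic ring replaces a group of 4 heavy atoms without a ring on an aromatic carbon.

Compound 4 `O=C1O[C@H]([C@@H](O)Cn2cc(CCCCl)nn2)C(OCc2ccccc2)=C1OCc1ccccc1` is not yet measured. It differs from compound 3 by 3-chloropropyl in place of 2-methoxyphenyl on an aromatic carbon. This is close to the reverse of the measured step: a ring-bearing group of 8 heavy atoms leaves and a chain of 4 heavy atoms without a ring enters at the same kind of position. A large rise in number is therefore expected in this assay, though the entering chain is not the group of compound 2, so the size is uncertain.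

Compound 4 is estimated at 5000 nM, within 800 nM to 30000 nM, which is an expected step of a 100-fold higher number from compound 3 to compound 4 (2.00 log units; beyond the scatter).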

Compound 4, half-maximal inhibitory concentration: 27100 nM
Beside the measured number, compound 4's estimate is 5.4-fold (0.73 log units) below it, within the range that was stated.
By their numbers in this assay, from the lowest: compound 1; then compound 3; then compounds 2 and 4 (each within the scatter of the next).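

In this assay, the step to 3-chloropropyl on this aromatic carbon (a 540-fold higher number from compound 3 to compound 4 (2.73 log units; beyond the scatter)) shows that a change of this size does not depend on silicon, since a ringless group without silicon in place of 2-methoxyphenyl gives a large step as well. The two ringless groups at this place cannot be told apart (a 1.4-fold higher number from compound 2 to compound 4 (0.13 log units; within the scatter)), so exchanging the silicon-bearing group of compound 2 for 3-chloropropyl leaves the read-out within the scatter. Going by these compounds alone, compound 1 carries its aromatic ring on a sulfonylamino arm, and the step that removes this arm is also large (a 1400-fold higher number from compound 1 to compound 4 (3.13 log units; beyond the scatter)), so across these four compounds each group with an aromatic ring goes with a low number and each group without one goes with a high number, with no compound against this pattern.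

On these data alone, it remains open whether the ring itself or the size of the group governs these steps: a plain phenyl, a cyclohexyl group or a longer chain ending in an amine at this place would help separate the two. No measurement among those available bears on the cause of these steps.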